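The source may hold more compounds than are shown below. What is called first, only, known or untested is meant among the compounds shown, and "the series" means these compounds.

Measured so far in the series:
compound 1 `COc1cc(-c2nn(-c3cccc(NC(=O)c4cccc(C(F)(F)F)c4)c3)cc2-c2ccncc2)ccc1Cl`: > 50000 nM
compound 2 `O=C(Nc1cccc(-n2cc(-c3ccncc3)c(-c3ccc(Cl)c(O)c3)n2)c1)Nc1cc(C(F)(F)F)cc(C(F)(F)F)c1`: 2800 nM

In a functional assay on U-251 cells (Homo sapiens) for inhibition, read by sulforhodamine B assay, with a stated time of 48 h (a higher number here means that more compound is tolerated, a lower number that less compound is tolerated), compound 1 gives > 50000 nM, which is a limit of the assay and not a number. Compound 1 thus stands at the limit of > 50000 nM in this assay, at which 1 of the 2 values shown sits. In this assay compound 2 gives 2800 nM. For the measured compounds named here, compound 2 and compound 1 differ in more than one place, so no single measured step joins them; their two values show only that compound 2 reaches a numbered concentration where compound 1 does not.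

Compound 3 `COc1cc(-c2nn(-c3cccc(NC(=O)Nc4ccc(Cl)c(C(F)(F)F)c4)c3)cc2-c2ccncc2)ccc1Cl` is not yet measured. From compound 1 it differs by (4-chloro-3-(trifluoromethyl)phenyl)amino in place of 3-(trifluoromethyl)phenyl on a carbonyl carbon. Because compound 2, which also carries an arylamino group on its carbonyl carbon, gives 2800 nM, the step from compound 1 to compound 3 is expected to run toward a lower concentration, beyond the scatter. The expected step is an at least 8.3-fold lower number from compound 1 to compound 3 (0.92 log units; beyond the scatter). Compound 3 is estimated at 6000 nM, with a range from 1500 nM to 30000 nM.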

Compound 3, concentration lethal to 50% of the cells: 24700 nM
Compound 3: the middle estimate sits 4.1-fold (0.61 log units) below what was measured; measured number inside the range.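

In this assay, placing (4-chloro-3-(trifluoromethyl)phenyl)amino instead of 3-(trifluoromethyl)phenyl on the carbonyl carbon gives an at least 2.0-fold lower number from compound 1 to compound 3 (0.30 log units; that floor lies within the scatter). For the compounds shown here, this is the first single-place change, and it shows that a change at this carbonyl carbon alone can bring the core of compound 1 to a numbered value, with compound 3 at 24700 nM. The size of the step remains a floor, as compound 1 gives a limit of the assay and not a number: the limit of > 50000 nM in this assay, at which 1 of the 3 values shown sits.

The change brings in the amino nitrogen and the chlorine together, so the compounds shown do not assign the step to either one. A plain 3-(trifluoromethyl)phenylamino group on the same carbonyl carbon would separate the two, and a bromine or methyl group in place of the chlorine would test whether that atom matters at all.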